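The source may report more compounds than this note shows. Statements on the series, on what has been measured and on what is new or still open speak of the compounds shown alone.

Compound 1 `CC(C(=O)NCc1ccc(C(C)(C)C)nc1SC1CCCC1)c1ccc(NS(C)(=O)=O)c(F)c1`: 2.5 nM
Compound 2 `CC(C(=O)NCc1ccc(C(C)(C)C)nc1SCc1ccccc1Cl)c1ccc(NS(C)(=O)=O)c(F)c1`: 3.8 nM

In an assay on cells for antagonist activity at transient receptor potential cation channel subfamily V member 1 (Homo sapiens), read by FLIPR and calcium flux, with a stated time of 6 min (on this read-out higher numbers stand for weaker inhibition and lower numbers for stronger inhibition), compound 1 gives 2.5 nM, and compound 2 gives 3.8 nM. These two numbers lie within the scatter of one another, as the step of a 1.5-fold higher number from compound 1 to compound 2 (0.18 log units; within the scatter) shows, so compound 2 cannot be told apart from compound 1 on this read-out.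

Compound 3 `COc1ccc(CSc2nc(C(C)(C)C)ccc2CNC(=O)C(C)c2ccc(NS(C)(=O)=O)c(F)c2)cc1` is the next step. Its change is 4-methoxyphenyl in place of 2-chlorophenyl on a saturated chain carbon bound to a sulfur. Among the measured compounds shown here, only one measured step bears on it: the exchange of cyclopentyl for 2-chlorobenzyl on the sulfur, a 1.5-fold higher number from compound 1 to compound 2 (0.18 log units; within the scatter), which stayed within the scatter. That step changed the whole group on the sulfur, yet the number hardly moved. For the measured compounds named here, no measured step exchanges one group on the benzyl ring for another, so the expectation rests on that single step alone.

Compound 3 is therefore expected to stay close to compound 2, with a step of a 1.1-fold higher number from compound 2 to compound 3 (0.02 log units; within the scatter) in this assay, not beyond the scatter. The estimate for compound 3 is 4 nM, with a range from 1.5 nM to 12 nM.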

Compound 3, inhibition constant: 3.5 nM
Estimate against measurement, compound 3: 1.1-fold (0.06 log units) above, within the range that was stated.
By their numbers in this assay, from the lowest: compounds 1, 3 and 2 (each within the scatter of the next).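

Exchanging 2-chlorobenzyl for 4-methoxybenzyl on the sulfur gives a 1.1-fold lower number from compound 2 to compound 3 (0.04 log units; within the scatter) in this assay, the first sign that the benzyl ring can carry a different group at a different ring position with no shift beyond the scatter. Replacing cyclopentyl with 4-methoxybenzyl gives a 1.4-fold higher number from compound 1 to compound 3 (0.15 log units; within the scatter) on the same read-out, so all three groups on the sulfur now cannot be told apart. No measurement is at hand to explain why they read alike.

As far as these compounds go, it remains open whether a much smaller group such as methyl, or a benzyl ring bearing an amine or a carboxylic acid, would also read alike. Compound 2 and compound 3 differ in both the ring group and its ring position, so 4-chlorobenzyl or 2-methoxybenzyl would be needed to separate the two.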